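The source may hold more compounds than are shown below. What is called first, only, known or untested is meant among the compounds shown, and "the series" means these compounds.

Measured compounds:
- compound 1, `Cc1c(C(=O)Nc2ccc(Oc3ccnc4[nH]ccc34)c(F)c2)nnn1-c1ccccc1`: in a functional assay on A549 cells (Homo sapiens) for cytotoxicity, read by MTT assay, with a stated time of 72 h (on this read-out lower numbers stand for stronger inhibition and higher numbers for weaker inhibition), compound 1 gives 360 nM
- compound 2, `COc1ccc(-n2nnc(C(=O)Nc3ccc(Oc4ccnc5[nH]ccc45)c(F)c3)c2C)cc1`: in this assay compound 2 gives 710 nM

Compound 2 holds the higher of the two numbers; its nearest neighbour is compound 1, and the step of a 2.0-fold higher number from compound 1 to compound 2 (0.29 log units; within the scatter) lies within the scatter, so no order is claimed between them.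

Compound 3, `Cc1c(C(=O)Nc2ccc(Oc3ccnc4[nH]ccc34)c(F)c2)nnn1-c1ccc(F)c(F)c1`, remains to be measured. It differs from compound 2 by 3,4-difluorophenyl in place of 4-methoxyphenyl on an aromatic nitrogen. For the measured compounds named here, no measured step involves a fluorine-bearing phenyl, so nothing bears directly on this change. Going by the values given here, the only step available on the same phenyl, a 2.0-fold higher number from compound 1 to compound 2 (0.29 log units; within the scatter), exchanged hydrogen for methoxy and stayed within the scatter. On that basis no step beyond the scatter is expected in this assay, in either direction. Compound 3 is therefore estimated at 500 nM, with a range from 150 nM to 1700 nM. The step of a 1.4-fold lower number from compound 2 to compound 3 (0.15 log units; within the scatter) that this estimate implies is expected to remain within the scatter.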

Compound 3, half-maximal inhibitory concentration: 570 nM
The estimate for compound 3 lay 1.1-fold (0.06 log units) below the measured number; low and high end bracket the measured number.
By their numbers in this assay, from the lowest: compounds 1, 3 and 2 (each within the scatter of the next).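

On the aromatic nitrogen of the five-membered ring, a halogen-bearing phenyl can now be compared with phenyl and 4-methoxyphenyl: in this assay the readings are a 1.2-fold lower number from compound 2 to compound 3 (0.10 log units; within the scatter) and a 1.6-fold higher number from compound 1 to compound 3 (0.20 log units; within the scatter). Neither change of the phenyl group, to 3,4-difluorophenyl from 4-methoxyphenyl or from phenyl, leaves the scatter, so no order among the three compounds can be claimed at this position. No available data bear on this result or offer an explanation for it.

The two fluorines enter together, so the compounds shown do not separate a single fluorine at either ring position from the pair. Also open, as far as these compounds go, is whether an amine or carboxylic acid on the phenyl, or a longer alkyl chain in place of the phenyl on that nitrogen, would give a step beyond the scatter.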